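The source may hold more compounds than are shown below. What is called first, only, known or untested is meant among the compounds shown, and "the series" means these compounds.

Compound 1 `O=C(Nc1ccccc1O)C1CCc2ccccc2N1C(=O)c1ccccc1Cl` gives 46900 nM
Compound 2 `CC(=O)N1c2ccccc2CCC1C(=O)Nc1cc(C(F)(F)F)cc(C(F)(F)F)c1` gives > 70000 nM (a limit)
Compound 3 `CCCC(=O)N1c2ccccc2CCC1C(=O)Nc1ccccc1C(F)(F)F` gives > 70000 nM (a limit)

All three were tested in a functional assay on NCI-H23 cells (Homo sapiens) for cytotoxicity, read by sulforhodamine B assay, with a stated time of 72 h (on this read-out lower numbers stand for stronger inhibition of growth and higher numbers for weaker inhibition of growth), and compared there. Compound 2 stands at the limit of > 70000 nM in this assay, at which 2 of the 3 values shown sit, and so has no number of its own. Compound 4 `O=C(Nc1cc(C(F)(F)F)cc(C(F)(F)F)c1)C1CCc2ccccc2N1` follows from compound 2 by hydrogen in place of acetyl on a nitrogen on an aromatic ring in a ring and carries hydrogen in place of acetyl. Among the compounds with values here, no measured step shows what such a change does. Within the data shown here, compound 1 at 46900 nM is the only compound with a number, so in this assay only a modest move toward stronger inhibition is expected, and a move within the scatter remains possible. The expected change is an at least 1.5-fold lower number from compound 2 to compound 4 (0.19 log units; that floor lies within the scatter) in that direction. Compound 4 is estimated at 45000 nM with an expected range from 12000 nM to 120000 nM.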

Compound 4, concentration for 50% growth inhibition: 8410 nM
Compound 4: middle estimate off by 5.4-fold (0.73 log units), on the high side, and the stated range ends above it.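

In this assay, hydrogen in place of acetyl on a nitrogen on an aromatic ring in a ring gives an at least 8.3-fold lower number from compound 2 to compound 4 (0.92 log units; beyond the scatter). Within the data shown here, this is the first readable step at this position, and it shows that growth inhibition here responds to the change, with the hydrogen giving the stronger inhibition in this pair. The step's size is only a floor because the value of compound 2 is a limit and not a number: the limit of > 70000 nM in this assay, at which 2 of the 4 values shown sit.

As far as these compounds go, what a methyl group or a longer acyl chain would do on this nitrogen stays open. So does whether the same change would give a similar step with the other amide groups of compound 1 or compound 3.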